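Aryl amide variation on a shared thiophene-free core? No — on the shared core

The compounds below may be only part of what the source reports. "The series", "measured", "known", "first", "only" and "open" are said of these compounds alone.

Measured so far, in a functional assay on MV4-11 cells (Homo sapiens) for antiproliferative activity; on this read-out lower numbers stand for stronger inhibition and higher numbers for weaker inhibition:
compound 1, `Cc1ccc(C(=O)Nc2sc3c(c2C(N)=O)CCCC3)cc1`, gives 450 nM;
compound 2, `COc1ccc(C(=O)Nc2sc3c(c2C(N)=O)CCCC3)cc1`, gives 1300 nM;
compound 3, `Cc1cccc(C(=O)Nc2sc3c(c2C(N)=O)CCCC3)c1`, gives 3200 nM.

The three share one core and differ only in the aryl amide part. Compound 1 to compound 2 is methoxy in place of methyl on an aromatic carbon, and the step is a 2.9-fold higher number from compound 1 to compound 2 (0.46 log units; beyond the scatter). Compound 1 to compound 3 is 3-methylphenyl in place of 4-methylphenyl on a carbonyl carbon, with the step of a 7.1-fold higher number from compound 1 to compound 3 (0.85 log units; beyond the scatter). Compound 3 stands highest of the three in this assay.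

Compound 4, `COc1cccc(C(=O)Nc2sc3c(c2C(N)=O)CCCC3)c1`, is not yet measured. Its difference from compound 3 is methoxy in place of methyl on an aromatic carbon. This is the same kind of change as compound 1 to compound 2, not the same: there the place is para to a large group, here meta to a large group. Starting from the value of compound 3, 3200 nM, the expected step to compound 4 is a 2.0-fold higher number from compound 3 to compound 4 (0.31 log units; beyond the scatter), resting on the earlier step of a 2.9-fold higher number from compound 1 to compound 2 (0.46 log units; beyond the scatter), set beside it with some allowance for the changed place. Compound 4 is thus estimated at 6500 nM, with a range from 2500 nM to 16000 nM.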

Compound 4, half-maximal inhibitory concentration: 1500 nM
Compound 4: the middle estimate sits 4.3-fold (0.64 log units) above what was measured; measured number outside the range, below it.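

In this assay, methoxy in place of methyl on an aromatic carbon, meta to a large group, gives a 2.1-fold lower number from compound 3 to compound 4 (0.33 log units; beyond the scatter). Set beside the earlier step, the change does not carry from one core to the other, and even the direction reverses: the same change on two cores in this assay, a 2.9-fold higher number (0.46 log units; beyond the scatter) from compound 1 to compound 2 and a 2.1-fold lower number (0.33 log units; beyond the scatter) from compound 3 to compound 4, 6.2-fold (0.79 log units) apart, beyond the scatter of two such steps. Going by these compounds alone, this rests on a single matched pair on each side, so it shows only that the step from one pair cannot be applied to the other; it does not show why they differ or how the change would behave on any further core.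

The compounds shown leave open how an ethoxy group, a chlorine or an amine would read in the same place. They also leave open whether either methoxy step holds with the shared core altered.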